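The source may report more compounds than this note shows. Statements on the series, on what has been measured and on what is new or still open speak of the compounds shown alone.

- compound 1 `C=CCc1cc(O)c(O)c(CN2CCC(CCO)CC2)c1` gives 40.6%
- compound 2 `C=CCc1ccc(OCc2cn(-c3ccc(C#N)cc3)nn2)c(O)c1` gives 62.5%

For the measured compounds named here, both numbers come from a functional assay on SK-N-SH cells (Homo sapiens) for inhibition, read by MTT assay, with a stated time of 72 h, tested at 50 uM (a lower number here means less inhibition of growth, a higher number more inhibition of growth at the concentration tested), and are the only measurements so far. Compound 2 stands highest of the two, and its lead over compound 1 lies beyond the usual scatter. The two compounds differ in more than one place, so that gap cannot be pinned on any single group.

The next compound to be tested is compound 3 `C=CCc1ccc(OCc2cn(-c3ccccc3Cl)nn2)c(O)c1`, which carries 2-chlorophenyl in place of 4-cyanophenyl on an aromatic nitrogen and is otherwise the same as compound 2. Going by the values given here, no measured pair shows what such a swap does, so the expectation starts from compound 2 (62.5%) and allows only a small drop, within the scatter. The expected change is a number 5.5 percentage points lower from compound 2 to compound 3 (within the scatter) in this assay for now. Compound 3 is estimated at 57%, with an expected range from 38% to 74% in this measurement.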

Compound 3, percent growth inhibition at one concentration: 42.8%
Beside the measured number, compound 3's estimate is 14.2 percentage points above it, and the stated range covers the measured number.
By their numbers in this assay, from the lowest: compounds 1 and 3 (each within the scatter of the next); then compound 2.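

For the compounds shown here, replacing 4-cyanophenyl with 2-chlorophenyl on the aromatic nitrogen gives a number 19.7 percentage points lower from compound 2 to compound 3 (beyond the scatter) in this assay and is the first direct comparison at this position. Although modest, the step lies beyond the usual scatter, so the group carried on this nitrogen matters for growth inhibition at the concentration tested, at least for this pair. No measurement here gives a reason for the drop.

This single swap changes both the substituent on the phenyl ring, chlorine for nitrile, and the number that marks its place, so the two changes cannot be separated. As far as these compounds go, a 4-chlorophenyl or a 2-cyanophenyl on the same nitrogen would pull them apart, and a plain phenyl would show what either substituent adds, but how any of these behaves remains open.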